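Flipping one stereocentre in compound 2

A few compounds are considered here, and "the series" means these few. Any claim that something is new, unique, unknown or untested is made for them only; others in the source may bear on it.

In an assay on CHO cells for inhibition of bone morphogenetic protein 1 (Homo sapiens), with stated times of 10 min and 60 min (on this read-out lower numbers stand for stronger inhibition and higher numbers for weaker inhibition), three compounds have been measured so far. Compound 1 `CCCCC[C@H](CN(O)C=O)C(=O)NCNC(=O)c1ccc(-c2cccc(OC)c2)o1` gives 20 nM, compound 2 `CCCCC[C@@H](C(=O)NCNC(=O)c1cc2cccc(OC)c2o1)[C@@H](CC)N(O)C=O` gives 126 nM, and compound 3 `COc1cccc2cc(C(=O)NCNC(=O)CCN(O)C=O)oc12` gives 6300 nM. Compound 2 therefore sits second highest of the three numbers; its nearest neighbour is compound 1, whose lower number lies beyond the scatter, and its furthest is compound 3, whose higher number also lies beyond the scatter.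

Compound 4 `CCCCC[C@@H](C(=O)NCNC(=O)c1cc2cccc(OC)c2o1)[C@H](CC)N(O)C=O` has not yet been measured. It differs from compound 2 in that (the two compounds have the same atoms and bonds and differ only in configuration as drawn: 1 of 2 stereo elements differ; a stereocentre at a saturated chain carbon is drawn R in compound 2 and S in compound 4). Going by the values given here, no pair among the measured compounds differs in such a way, so the data give no direct guide to the size of this step.

A change of configuration at a single centre can leave the number where it is or move it a long way in either direction. Compound 2 is expected to lose some of its inhibition on inversion, with the step from compound 2 to compound 4 estimated at a 3.2-fold higher number from compound 2 to compound 4 (0.50 log units; beyond the scatter). Compound 4 is accordingly expected to give about 400 nM in this assay, with a wide range from 50 nM to 4000 nM.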

Compound 4, half-maximal inhibitory concentration: > 10000 nM
Compound 4 gave a limit, no number; the forecaster's own chance of this, stated with the estimate: 5%; middle value at least 25-fold (1.39 log units) from the limit.
By their numbers in this assay, from the lowest: compound 1; then compound 2; then compound 3. At a limit, above all of these: compound 4.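

In this assay compound 4 gives > 10000 nM, which is a limit of the assay and not a number. Inverting the stereocentre at the saturated chain carbon from R to S produces an at least 79-fold higher number from compound 2 to compound 4 (1.89 log units; beyond the scatter), the first step in this series that can be read as a single change and one that lies beyond the scatter. It shows that, in this assay, the configuration at this carbon can by itself separate a measured number from a limit, with nothing entering or leaving the structure: the fact that compounds 2 and 4 differ only in the configuration as drawn

How much further the true value of compound 4 lies beyond what is printed remains unknown, so the step has a lower bound but no upper one: the limit of > 10000 nM in this assay, at which 1 of the 4 values shown sits. The compounds shown also leave open whether a longer chain or a carboxylic acid at this carbon would change the number in either configuration, and whether inverting the other stereocentre, the second of the two stereo elements in compound 2, would produce a step of similar size.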